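Amino Group Replaced by Hydrogen: Expected Cytotoxicity of Compound 4

This account rests on a few compounds, and the source may have more. Where it says the series, first, only, none or still open, it means among the compounds named here.

Measured compounds:
compound 1 `COc1ccc(/C=C/C(=O)c2cccc(-c3cccc(F)c3)c2)cc1` gives 4510 nM
compound 2 `Nc1ccc(C(=O)/C=C/c2ccc(O)c(F)c2)cc1-c1ccc(F)cc1` gives 31700 nM
compound 3 `COc1ccc(/C=C/C(=O)c2ccc(N)c(-c3ccc(F)cc3)c2)cc1` gives 7230 nM

In a functional assay on SW480 cells (Homo sapiens) for cytotoxicity, read by sulforhodamine B assay, with a stated time of 48 h (a lower number here means a stronger inhibitor, a higher number a weaker inhibitor), compound 3 gives 7230 nM, a number that lies within the scatter of compound 1 and well below compound 2. Compound 4 `COc1ccc(/C=C/C(=O)c2cccc(-c3ccc(F)cc3)c2)cc1` differs from compound 3 in one place: hydrogen in place of amino on an aromatic carbon. Among the measured compounds shown here, the only measured step, a 4.4-fold lower number from compound 2 to compound 3 (0.64 log units; beyond the scatter), changes the group on a double-bonded chain carbon and leaves the amino untouched, so no measured step bears directly on this change. With nothing pointing either way, the step of a 1.3-fold lower number from compound 3 to compound 4 (0.12 log units; within the scatter) is expected to stay within the scatter. Compound 4 is therefore estimated at 5500 nM, with a range from 2000 nM to 15000 nM.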

Compound 4, half-maximal inhibitory concentration: 8350 nM
Compound 4: the middle estimate sits 1.5-fold (0.18 log units) below what was measured; the measured number falls inside the stated range.
By their numbers in this assay, from the lowest: compounds 1, 3 and 4 (each within the scatter of the next); then compound 2.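

In this assay, hydrogen in place of amino gives a 1.2-fold higher number from compound 3 to compound 4 (0.06 log units; within the scatter), so on this aromatic carbon, ortho to a 4-fluorophenyl group, the amino can go with no change that stands out from the scatter. Likewise, 4-fluorophenyl in place of 3-fluorophenyl gives a 1.9-fold higher number from compound 1 to compound 4 (0.27 log units; within the scatter), so that swap also shows no readable change. No measurement at hand offers an explanation for either result.

Amino and hydrogen are the only two groups compared on this carbon. From the compounds shown here alone, whether a carboxylic acid or a dimethylamino group there would move the number remains open.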